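Hydrogen for nitro in the oxazolone series

The source may hold more compounds than are shown below. What is called first, only, known or untested is meant among the compounds shown, and "the series" means these compounds.

compound 1 `O=C1OC(c2ccc(Cl)c([N+](=O)[O-])c2)=N/C1=C\c1ccncc1`: in an assay on isolated protein for inhibition of Death-associated protein kinase 3 (Homo sapiens), tested at 10 uM (on this read-out higher numbers stand for a stronger effect at the one concentration tested and lower numbers for a weaker effect), compound 1 gives 10%
compound 2 `O=C1N=C(N2CCCCC2)S/C1=C\c1cccnc1`: in this assay compound 2 gives 29%
compound 3 `O=C1OC(c2ccc([N+](=O)[O-])cc2)=N/C1=C\c1ccncc1`: in this assay compound 3 gives 2%

Compound 3 gives the smallest of the three numbers. Its nearest neighbour is compound 1, whose number lies within the scatter of it, so the two cannot be separated on this read-out. Compound 2, with a different core, lies beyond the scatter and is the only one of the three that clearly stands apart from compound 3.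

The next compound in the series is compound 4 `O=C1OC(c2ccccc2)=N/C1=C\c1ccncc1`. It differs from compound 3 in one place: hydrogen in place of nitro on an aromatic carbon.

Within the data shown here, no pair among the measured compounds differs in a single place, so there is no measured step to lean on for this change. With compound 3 already close to the floor of the read-out in this assay, the expected step from compound 3 to compound 4 is a number 3 percentage points higher from compound 3 to compound 4 (within the scatter), which is within the scatter and in no clear direction. Compound 4 is therefore estimated to give 5% in this assay, with a range from -8% to 20%.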

Compound 4, a percentage reported as inhibition, at one concentration (the size of the read-out at that concentration, not a potency): 1%
Estimate against measurement, compound 4: 4 percentage points above; measured number inside the range.
By their numbers in this assay, from the lowest: compounds 4, 3 and 1 (each within the scatter of the next); then compound 2.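

In this assay, hydrogen in place of nitro, on an aromatic carbon para to a large group, gives a number 1 percentage points lower from compound 3 to compound 4 (within the scatter). Among these compounds, this is the first single-place step in the oxazolone series, and it shows that on this read-out the nitro group cannot be told apart from plain hydrogen at this position: with the nitro group gone, compound 4 still gives 1%, so the low number of compound 3 does not rest on that group. No independent measurement on hand accounts for this flat step, so it stands as an observation only.

Going by these compounds, what remains open is whether any other group at this position, such as an amine, a carboxylic acid or a methoxy group, would move the number beyond the scatter, since two values this low say little about how the position responds to substitution in general. Among the compounds shown here, compound 2 has no partner differing from it in one place, so the single structural change that would account for its number in this assay cannot be identified from the compounds at hand.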